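Aryl sulfone series: adding cyclopropyl to compound 3

The compounds below may be only part of what the source reports. "The series", "measured", "known", "first", "only" and "open" are said of these compounds alone.

Measured values in an ADME assay for permeability, using PAMPA, at pH 7.4 (on this read-out higher numbers stand for higher permeability and lower numbers for lower permeability), for the series so far
- compound 1 `CCCCc1nc(=O)c(S(=O)(=O)c2ccc(-c3ccnc(NC(=O)C4CC4)c3)cc2)c(O)n1-c1c(OC)cccc1OC` gives 11 nm/s
- compound 2 `CCCCc1nc(=O)c(S(=O)(=O)c2ccc(-c3ccc(F)nc3)cc2)c(O)n1-c1c(OC)cccc1OC` gives 24 nm/s
- compound 3 `CCCCc1nc(=O)c(S(=O)(=O)c2ccccc2)c(O)n1-c1c(OC)cccc1OC` gives 1.5 nm/s

Compound 3 at 1.5 nm/s stands lowest of the three in this assay and is the starting point here. Compound 4 `CCCCc1nc(=O)c(S(=O)(=O)c2ccc(C3CC3)cc2)c(O)n1-c1c(OC)cccc1OC` carries cyclopropyl in place of hydrogen on an aromatic carbon, para to a large group. Among the compounds with values here, two measured steps bear on this change (a 7.3-fold lower number from compound 1 to compound 3 (0.87 log units; beyond the scatter); a 16-fold lower number from compound 2 to compound 3 (1.20 log units; beyond the scatter)), each with hydrogen in place of a pyridinyl group, so a rise is expected for compound 4, smaller than either and still beyond the scatter. The expected size is (a 3.3-fold higher number from compound 3 to compound 4 (0.52 log units; beyond the scatter)) on this estimate. The estimate for compound 4 is 5 nm/s with an expected range from 2.2 nm/s to 12 nm/s in this read-out.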

Compound 4, apparent permeability: 22 nm/s
Estimate against measurement, compound 4: 4.4-fold (0.64 log units) below; the measured number lies above the stated range.
By their numbers in this assay, from the lowest: compound 3; then compounds 1, 4 and 2 (each within the scatter of the next, the first and the last beyond it).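

In this assay the change gives a 15-fold higher number from compound 3 to compound 4 (1.17 log units; beyond the scatter) with cyclopropyl alone on this aromatic carbon, so a rise here needs neither a pyridinyl group nor a hydrogen-bond donor or acceptor. Cyclopropyl also stands level with both pyridinyl groups: a 1.1-fold lower number from compound 2 to compound 4 (0.04 log units; within the scatter) and a 2.0-fold higher number from compound 1 to compound 4 (0.30 log units; within the scatter) both lie within the scatter. Nothing available explains the rise. As far as these compounds go, whether it depends on the three-membered ring or on any carbon group at this place stays open. A methyl, a longer chain or an amine here would help separate these readings.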